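Notes on the step from compound 2 to compound 4

The compounds below may be only part of what the source reports. "The series", "measured", "known", "first", "only" and "open" are said of these compounds alone.

Measured in a functional assay on CCRF-CEM cells (Homo sapiens) for antiproliferative activity, with a stated time of 72 h; on this read-out higher numbers stand for weaker inhibition and lower numbers for stronger inhibition
- compound 1 (`OC[C@H]1O[C@@H](n2cnc3c(NCc4ccccc4F)ncnc32)[C@H](O)[C@@H]1O`) gives 4600 nM
- compound 2 (`OC[C@H]1O[C@@H](n2cnc3c(NCc4ccc(F)cc4)ncnc32)[C@H](O)[C@@H]1O`) gives 1250 nM
- compound 3 (`OC[C@H]1O[C@@H](n2cnc3c(NCc4ccccc4Br)ncnc32)[C@H](O)[C@@H]1O`) gives 12300 nM

Compound 2 holds the lowest of the three numbers. Next is compound 4 (`Cc1cccc(CNc2ncnc3c2ncn3[C@@H]2O[C@H](CO)[C@@H](O)[C@H]2O)c1`), with 3-methylphenyl in place of 4-fluorophenyl on a saturated chain carbon bound to a nitrogen on an aromatic ring. Two measured steps change this same group, a 3.7-fold lower number from compound 1 to compound 2 (0.57 log units; beyond the scatter) and a 9.8-fold higher number from compound 2 to compound 3 (0.99 log units; beyond the scatter), and both are modest. The 4-fluorophenyl compound holds the lower number in each. Among the compounds with values here, no measured compound carries 3-methylphenyl, so the direction is only tentative. A modest rise is expected in this assay, with the estimated step being a 2.4-fold higher number from compound 2 to compound 4 (0.38 log units; beyond the scatter). For compound 4 the estimate is 3000 nM with an expected range from 900 nM to 10000 nM.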

Compound 4, half-maximal inhibitory concentration: 19100 nM
Beside the measured number, compound 4's estimate is 6.4-fold (0.80 log units) below it, outside the stated range (above it).
By their numbers in this assay, from the lowest: compound 2; then compound 1; then compounds 3 and 4 (each within the scatter of the next).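

In this assay, within the data shown here, 3-methylphenyl on this saturated chain carbon gives a 15-fold higher number from compound 2 to compound 4 (1.18 log units; beyond the scatter), a large step, and a 4.2-fold higher number from compound 1 to compound 4 (0.62 log units; beyond the scatter), so this place responds more strongly than the earlier steps alone showed. Against 2-bromophenyl it gives a 1.6-fold higher number from compound 3 to compound 4 (0.19 log units; within the scatter), so the one group here without a halogen cannot be told apart from that bromo group, and a high number does not depend on bromine. Nothing available explains these steps. On these data alone, whether the change follows the methyl group or its ring location stays open, and 4-methylphenyl and 3-fluorophenyl would separate the two; an amine on the ring is also untested here.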